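A few compounds are considered here, and "the series" means these few. Any claim that something is new, unique, unknown or untested is made for them only; others in the source may bear on it.

Working notes on the series sharing the core of compound 3. In an assay on HEK293 cells for inhibition of Steryl-sulfatase (Homo sapiens), tested at 0.1 uM (a lower number here means a weaker effect, a higher number a stronger effect of the compound at the concentration tested), compound 3 `CC(C)CCN(CCC(C)C)c1cccc(C(=O)N2CCc3ccc(OS(N)(=O)=O)cc3C2)c1` gives 32.3%, the highest of the three numbers in hand; compound 1 `CCN(Cc1ccc(F)cc1)c1cccc(C(=O)N2CCc3ccc(OS(N)(=O)=O)cc3C2)c1` gives 10.9% and compound 2 `CN(C)CCN(CCN(C)C)c1cccc(C(=O)N2CCc3ccc(OS(N)(=O)=O)cc3C2)c1` gives 0%. The steps run a number 21.4 percentage points higher from compound 1 to compound 3 (beyond the scatter), a number 32.3 percentage points higher from compound 2 to compound 3 (beyond the scatter) and a number 10.9 percentage points lower from compound 1 to compound 2 (beyond the scatter). Compound 4 `CCN(Cc1cccnc1)c1cccc(C(=O)N2CCc3ccc(OS(N)(=O)=O)cc3C2)c1` differs from compound 3 by ethyl((pyridin-3-yl)methyl)amino in place of diisopentylamino on an aromatic carbon. The step that bears most on this change is a number 21.4 percentage points higher from compound 1 to compound 3 (beyond the scatter), since compound 4 is closer to compound 1 than to compound 3, and a number 10.9 percentage points lower from compound 1 to compound 2 (beyond the scatter) points the same way. A drop of a number 24.3 percentage points lower from compound 3 to compound 4 (beyond the scatter) is therefore expected in this assay. Compound 4 is estimated at 8%, within 0% to 20%.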

Compound 4, a percentage reported as inhibition, at one concentration (the size of the read-out at that concentration, not a potency): 14.3%
Compound 4: middle estimate off by 6.3 percentage points, on the low side; measured number inside the range.
By their numbers in this assay, from the lowest: compound 2; then compounds 1 and 4 (each within the scatter of the next); then compound 3.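

In this assay, the ring on the ethyl-substituted amine can be pyridin-3-yl or 4-fluorophenyl with no step beyond the scatter, a number 3.4 percentage points higher from compound 1 to compound 4 (within the scatter). The pyridine-bearing amine still falls short of diisopentylamino, a number 18 percentage points lower from compound 3 to compound 4 (beyond the scatter), yet stands clear of bis(2-(dimethylamino)ethyl)amino, a number 14.3 percentage points higher from compound 2 to compound 4 (beyond the scatter). Nothing available explains these differences. Going by these compounds, it remains open whether a piperidine or a dibutylamino group on this aromatic carbon would match diisopentylamino, and whether a carboxylic acid on the pyridin-3-yl ring would change the read-out.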